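Working notes: aryl groups on the sulfonamide nitrogen

The source may report more compounds than this note shows. Statements on the series, on what has been measured and on what is new or still open speak of the compounds shown alone.

Values in a functional assay on cells (leukaemia cell line, Homo sapiens) for inhibition, read by sulforhodamine B assay, with a stated time of 48 h; a higher number here means a weaker inhibitor of growth, a lower number a stronger inhibitor of growth:
- compound 1 `O=S(=O)(Nc1ccc(Cl)cc1Cl)c1ccc(-c2cnc(C3CC3)o2)cc1`: 481 nM
- compound 2 `Cc1cc(NS(=O)(=O)c2ccc(-c3cnc(C4CC4)o3)cc2)ccc1Cl`: 216 nM
- compound 3 `O=S(=O)(Nc1cc(Cl)ccc1Cl)c1ccc(-c2cnc(C3CC3)o2)cc1`: 1020 nM

Compound 3 stands highest of the three. The steps up to it are a 2.1-fold higher number from compound 1 to compound 3 (0.33 log units; beyond the scatter) and a 4.7-fold higher number from compound 2 to compound 3 (0.67 log units; beyond the scatter).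

Next is compound 4 `O=S(=O)(Nc1cc(F)cc(F)c1)c1ccc(-c2cnc(C3CC3)o2)cc1`: 3,5-difluorophenyl in place of 2,5-dichlorophenyl on a sulfonamide nitrogen. Among the compounds with values here, no measured step tests this exact change. The nearest evidence is the other changes at that place, a 2.2-fold lower number from compound 1 to compound 2 (0.35 log units; beyond the scatter) and the two above, all modest. With compound 3 at the top of this small range, a modest fall in this assay is expected, though a flat result remains possible. The expected change is a 1.9-fold lower number from compound 3 to compound 4 (0.27 log units; within the scatter). Compound 4 is estimated at 550 nM, with an expected range of 170 nM to 1800 nM.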

Compound 4, concentration for 50% growth inhibition: 2140 nM
Compound 4: middle estimate off by 3.9-fold (0.59 log units), on the low side; the measured number lies above the stated range.
By their numbers in this assay, from the lowest: compound 2; then compound 1; then compound 3; then compound 4.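

In this assay, within the data shown here, compound 4, the only one whose aryl group carries fluorine rather than chlorine, has the highest number of the four, with a 2.1-fold higher number from compound 3 to compound 4 (0.32 log units; beyond the scatter) and a 4.4-fold higher number from compound 1 to compound 4 (0.65 log units; beyond the scatter) and a 9.9-fold higher number from compound 2 to compound 4 (1.00 log units; beyond the scatter) as its steps. The change replaces chlorine with fluorine and also alters the substitution pattern, so these two differences cannot be separated here. No available evidence explains the rise.

From the compounds shown here alone, whether 3,5-dichlorophenyl would track with compound 4 or with the chlorinated compounds remains open. So does the outcome of an amine or a carboxylic acid on this aryl ring.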